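A few compounds are considered here, and "the series" means these few. Any claim that something is new, unique, unknown or untested is made for them only; others in the source may bear on it.

Measured in a functional assay on MCF7 cells (Homo sapiens) for inhibition; on this read-out lower numbers stand for stronger inhibition and higher numbers for weaker inhibition:

- Compound 1 `O=C(CC(CC(=O)NC1Cc2ccccc2C1)c1ccccc1)NCCN1CCCCC1`: > 100000 nM
- Compound 2 `CCNCCNC(=O)CC(CC(=O)N(CC)C1Cc2ccccc2C1)c1ccccc1`: > 100000 nM

Among the compounds with values here, only two compounds have been measured in this assay, and neither gives a number. Compound 1 reads > 100000 nM, which is a limit of the assay. Compound 2 reads > 100000 nM, which is also a limit of the assay. Compound 2 therefore stands with compound 1, and the whole of the data comes down to the limit of > 100000 nM in this assay, at which 2 of the 2 values shown sit.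

Compound 3 `CCN(C(=O)CC(CC(=O)NCCN1CCCCC1)c1ccccc1)C1Cc2ccccc2C1` has not yet been measured. It differs from compound 2 by one change: piperidin-1-yl in place of ethylamino on a saturated chain carbon, two bonds along the chain from an amide-type nitrogen. In words, piperidin-1-yl takes the place of ethylamino on a saturated chain carbon, two bonds along the chain from an amide-type nitrogen.

Within the data shown here, no step between measured compounds is available to size this change. The expectation rests on compound 2, whose > 100000 nM is a limit. No step beyond the scatter is expected in this assay, and no direction is favoured. The expected step is a number no higher from compound 2 to compound 3 (the limit leaves the size open). For compound 3 the estimated value is 100000 nM, with an expected range of 40000 nM to 250000 nM.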

Compound 3, half-maximal inhibitory concentration: > 100000 nM
Compound 3: only a limit was reported (the forecaster's own chance of this, stated with the estimate: 75%); the middle value sits exactly at the limit.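

In this assay compound 3 gives only a limit, like compound 1 and compound 2, so no step can be read between compound 3 and either of them, and the data stay where they were: the limit of > 100000 nM in this assay, at which 3 of the 3 values shown sit.

The compounds shown leave open whether either change, piperidin-1-yl in place of ethylamino or ethyl in place of hydrogen, alters inhibition at all.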